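The source may report more compounds than this note shows. Statements on the series, on what has been measured and on what is new or still open speak of the compounds shown alone.

Compound 2 `CNC(=O)c1cc(Oc2ccc3nc(Nc4cccc(C(C)C)c4)ncc3c2)ccn1` is the starting point of this pair. In an ADME assay on Caco-2 cells (Homo sapiens) for permeability, in the apical to basolateral direction (on this read-out higher numbers stand for higher permeability and lower numbers for lower permeability), compound 2 gives < 1 10^-6 cm/s, which is a limit of the assay and not a number. Compound 1 `CNC(=O)c1cc(Oc2ccc3nc(Nc4cccc(C(C)(C)C)c4)ncc3c2)ccn1` is the one measured relative to it. In this assay compound 1 gives < 1 10^-6 cm/s, again a limit. Within the data shown here, the single measured step, a step that the two limits leave unreadable from compound 1 to compound 2, is therefore not readable in size, since both of its ends sit at the limit of < 1 10^-6 cm/s in this assay, at which 2 of the 2 values shown sit. Compound 3 `CNC(=O)c1cc(Oc2ccc3nc(Nc4ccc(Br)cc4)ncc3c2)ccn1` carries the change (4-bromophenyl in place of 3-isopropylphenyl on a nitrogen on an aromatic ring). No measured step in this assay bears on this exchange, so the numbers shown give no direction and no size beyond the scatter for it, and the two limits only tell where compound 2 starts. Compound 3 is estimated at 0.8 10^-6 cm/s, with a range from 0.2 10^-6 cm/s to 3 10^-6 cm/s, and with a fair chance that the assay again reports only a limit. The expected step is a step that the limit leaves unreadable from compound 2 to compound 3.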

Compound 3, apparent permeability: < 1 10^-6 cm/s
Compound 3: a limit, no number; the forecaster's own chance of this, stated with the estimate: 60%; the middle value lies beyond the limit too.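

In this assay compound 3 gives only a limit, as do compound 1 and compound 2, so no step among the three can be read in size: the limit of < 1 10^-6 cm/s in this assay, at which 3 of the 3 values shown sit.

On these data alone, how far apart the three compounds lie, and in which direction 4-bromophenyl in place of 3-isopropylphenyl moves the read-out, stays open.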